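Replacing butylamino with hydroxy in a weakly active compound

The source may hold more compounds than are shown below. What is called first, only, known or untested is meant among the compounds shown, and "the series" means these compounds.

Compound 1 `CCOC(=O)C(=O)C(CC)NC(=O)C(CC(C)C)NC(=O)C(c1ccccc1)c1ccccc1` gives > 100000 nM in a functional assay for inhibition, with Rattus norvegicus as the target, at pH 7.35 (on this read-out lower numbers stand for stronger inhibition and higher numbers for weaker inhibition), and that value is a limit of the measurement, not a number. In this assay compound 2 `CCOC(=O)C(=O)[C@H](CC)NC(=O)[C@H](CC(C)C)NC(=O)[C@H](CC(C)C)NS(=O)(=O)c1ccc2ccccc2c1` gives 100000 nM and compound 3 `CCCCNC(=O)C(=O)C(CC)NC(=O)C(CC(C)C)NC(=O)OCc1ccccc1` gives 35000 nM as the lowest number shown, a gap to compound 2 that lies beyond the usual scatter.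

Compound 4 `CCC(NC(=O)C(CC(C)C)NC(=O)OCc1ccccc1)C(=O)C(=O)O` differs from compound 3 in one place (hydroxy in place of butylamino on a carbonyl carbon): hydroxy stands in place of butylamino on a carbonyl carbon, so butylcarbamoyl becomes carboxy. Going by the values given here, no measured pair shows this change, so the expectation rests on the values alone. Compound 3 at 35000 nM already holds the lowest number, and the other two sit higher, so a modest move towards weaker inhibition is expected rather than a gain. The estimated step is a 2.3-fold higher number from compound 3 to compound 4 (0.36 log units; beyond the scatter) and it may come out only just beyond the scatter. For compound 4 the estimate is 80000 nM with an expected range from 20000 nM to 250000 nM in this measurement.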

Compound 4, half-maximal inhibitory concentration: 100000 nM
Compound 4: the middle estimate sits 1.3-fold (0.10 log units) below what was measured; measured number inside the range.
By their numbers in this assay, from the lowest: compound 3; then compounds 2 and 4 (each within the scatter of the next).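

In this assay the change on this carbonyl carbon can now be read directly, and hydroxy in place of butylamino gives a 2.9-fold higher number from compound 3 to compound 4 (0.46 log units; beyond the scatter) as a modest step towards weaker inhibition. At this position, then, butylamino serves better than hydroxy, although compound 3 at 35000 nM in this pair is still a weak inhibitor. The true size of the step may not be fully captured, because compound 4 stands at the value where the read-out reaches its limit: the limit of > 100000 nM in this assay, at which 1 of the 4 values shown sits.

Going by these compounds, what remains open is whether the butyl chain matters or simply any group joined through nitrogen, which a methylamino, a benzylamino or a plain amino group on this carbon would help to separate. An ethoxy group here, on the core of compound 3, would also show how the ethyl esters compare directly with this pair.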